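This account rests on a few compounds, and the source may have more. Where it says the series, first, only, none or still open, it means among the compounds named here.

Measured so far:
- compound 1, `COc1ccc([C@@H]2CC(=O)c3c(O)cc(OCc4cn(Cc5cccc(Cl)c5)nn4)cc3O2)cc1O`, gives 18200 nM
- compound 2, `COc1ccc([C@@H]2C/C(=N\O)c3c(O)cc(OCc4cn(Cc5ccccc5F)nn4)cc3O2)cc1O`, gives 5710 nM

Both were tested in a functional assay on RAW264.7 cells (Mus musculus) for inhibition, read by Griess assay, with stated times of 2 h and 24 h; a higher number here means a weaker inhibitor, a lower number a stronger inhibitor. Compound 2 has the lower number of the two; compound 1 sits higher, and that gap lies beyond the usual scatter. Compound 3, `COc1ccc([C@@H]2C/C(=N\O)c3c(O)cc(OCc4cn(Cc5ccccc5Cl)nn4)cc3O2)cc1O`, differs from compound 2 in one place: chloro in place of fluoro on an aromatic carbon. Among the measured compounds shown here, no measured step of this kind is available, so the step from compound 2 to compound 3 is expected to stay within the scatter, with no clear direction, giving a 1.1-fold lower number from compound 2 to compound 3 (0.06 log units; within the scatter). Compound 3 is therefore estimated at 5000 nM, within a range of 2000 nM to 12000 nM.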

Compound 3, half-maximal inhibitory concentration: 13400 nM
Compound 3: the middle estimate sits 2.7-fold (0.43 log units) below what was measured, outside the stated range (above it).
By their numbers in this assay, from the lowest: compound 2; then compounds 3 and 1 (each within the scatter of the next).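

In this assay, the change from 2-fluorobenzyl to 2-chlorobenzyl gives a 2.3-fold higher number from compound 2 to compound 3 (0.37 log units; beyond the scatter), a modest step but one beyond the scatter. Among the compounds shown here, this is the first direct reading of this position, showing that exchanging one halogen atom for another here weakens inhibition, whereas compound 1 and compound 2 differ in more than one place. Nothing available explains this difference between fluoro and chloro.

Going by these compounds, whether a methyl, a methoxy or an amine at this ring carbon would give a lower number remains open. So does how a plain unsubstituted phenyl would compare.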